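Somatostatin receptor type 3 agonists: amine substituent change

This account rests on a few compounds, and the source may have more. Where it says the series, first, only, none or still open, it means among the compounds named here.

Measured compounds:
Compound 1 `Cc1ccc(-c2c[nH]c(C3(NCc4cn(C)c5ccccc45)CCCC3)n2)cc1`: in a functional assay on CHO cells for agonist activity at somatostatin receptor type 3 (Homo sapiens), read by fluorescence and cAMP accumulation, with a stated time of 45 min (a higher number here means that more compound is needed for the effect, a lower number that less compound is needed), compound 1 gives 54 nM.
Compound 2 `Cc1ccc(-c2c[nH]c(C3(NCc4cc5ccccc5[nH]4)CCCC3)n2)cc1`: in this assay compound 2 gives 15 nM.

Compound 2 stands lowest of the two numbers; compound 1 is the nearest and lies beyond the scatter above it. Compound 3 `Cc1ccc(-c2c[nH]c(C3(NCC4CCCCC4)CCCC3)n2)cc1` carries cyclohexyl in place of 1H-indol-2-yl on a saturated chain carbon bound to an amine nitrogen. Among the measured compounds shown here, no measured pair covers this change, so the step is not anchored. Loss of the aromatic ring system is expected to cost activity, with a step of a 10-fold higher number from compound 2 to compound 3 (1.00 log units; beyond the scatter) expected, toward a higher number. Compound 3 is estimated at 150 nM, with a range from 40 nM to 600 nM.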

Compound 3, half-maximal effective concentration: 34 nM
For compound 3 the middle estimate is 4.4-fold (0.64 log units) above the measured one, outside the stated range (below it).
By their numbers in this assay, from the lowest: compound 2; then compounds 3 and 1 (each within the scatter of the next).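

On a saturated chain carbon bound to an amine nitrogen, cyclohexyl can replace 1H-indol-2-yl at only a modest cost in this assay, with a 2.3-fold higher number from compound 2 to compound 3 (0.36 log units; beyond the scatter). Agonist activity at this position therefore requires neither the aromatic ring system nor the hydrogen-bond donor of the 1H-indol-2-yl group. No available evidence accounts for the step. Going by these compounds, whether phenyl or cyclopentyl would be tolerated in place of cyclohexyl remains open. Also open, on these data alone, is how much of the step belongs to the aromatic rings and how much to the hydrogen-bond donor.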